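Three methyls on the sulfonyl ring: what to expect

A few compounds are considered here, and "the series" means these few. Any claim that something is new, unique, unknown or untested is made for them only; others in the source may bear on it.

Measured so far in a functional assay on MCF7 cells (Homo sapiens) for inhibition, read by MTT assay, with a stated time of 48 h; a lower number here means a stronger inhibitor, a higher number a weaker inhibitor:
- compound 1 `COc1ccc(CN(c2cc(OC)c(OC)c(OC)c2)S(=O)(=O)c2ccc(C)cc2)cc1` gives 10100 nM
- compound 2 `COc1ccc(CN(c2cc(OC)c(OC)c(OC)c2)S(=O)(=O)c2ccccc2)cc1` gives > 50000 nM
- compound 3 `COc1ccc(CN(c2cc(OC)c(OC)c(OC)c2)S(=O)(=O)c2ccc(C(C)(C)C)cc2)cc1` gives 32700 nM

The value of compound 2 is a limit of this assay, not a number, and it sits at the limit of > 50000 nM in this assay, at which 1 of the 3 values shown sits. Compound 2 therefore stands at the weak end of what has been measured, while compound 1 gives the lowest number of the three.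

The step to compound 4 `COc1ccc(CN(c2cc(OC)c(OC)c(OC)c2)S(=O)(=O)c2c(C)cc(C)cc2C)cc1` is this change: 2,4,6-trimethylphenyl in place of phenyl on a sulfonyl sulfur. Within the data shown here, two measured steps bear on it. Removing the single methyl gave an at least 4.9-fold higher number from compound 1 to compound 2 (0.69 log units; beyond the scatter), so the methyl on that ring goes with a stronger inhibitor. Putting a tert-butyl in its place gave an at least 1.5-fold lower number from compound 2 to compound 3 (0.18 log units; that floor lies within the scatter), a floor that lies within the scatter. Adding three methyls at once has no direct precedent here; the nearest guide is compound 1, whose 10100 nM shows what one methyl does.

Compound 4 is therefore expected to give a number, not a limit, with a step of an at least 3.3-fold lower number from compound 2 to compound 4 (0.52 log units; beyond the scatter). The estimate for compound 4 is 15000 nM, with a range from 5000 nM to 50000 nM.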

Compound 4, half-maximal inhibitory concentration: 18700 nM
For compound 4 the middle estimate is 1.2-fold (0.10 log units) below the measured one; measured number inside the range.
By their numbers in this assay, from the lowest: compounds 1, 4 and 3 (each within the scatter of the next, the first and the last beyond it). At a limit, above all of these: compound 2.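

In this assay, the ring with three methyls gives an at least 2.6-fold lower number from compound 2 to compound 4 (0.42 log units; beyond the scatter), so the step away from phenyl holds when the ring carries more than a single methyl. Compound 2 is a limit of this assay, not a number, which makes that step a floor: the limit of > 50000 nM in this assay, at which 1 of the 4 values shown sits. Two further methyls give nothing that can be told apart from the single methyl, with a 1.9-fold higher number from compound 1 to compound 4 (0.27 log units; within the scatter), and the 2,4,6-trimethylphenyl ring also cannot be separated from the 4-(tert-butyl)phenyl ring, with a 1.7-fold lower number from compound 3 to compound 4 (0.24 log units; within the scatter).

As far as these compounds go, all the rings on the sulfonyl sulfur here carry only carbon groups, so the effect of an amine or a carboxylic acid on this ring remains open. From the compounds shown here alone, it is also open whether all three methyls of compound 4 are needed for its step from phenyl.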